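The compounds below may be only part of what the source reports. "The series", "measured", "known", "first", "only" and "open" are said of these compounds alone.

Measured so far in an in vivo ADME assay on the whole organism for pharmacokinetics, with Canis familiaris (Canis lupus familiaris) as the target; on this read-out lower numbers stand for narrower distribution and higher numbers for wider distribution into tissues:
compound 1 `Nc1noc2ccc(-n3nc(C(F)(F)F)c4c3C(=O)N(c3ccc(-c5ccccc5CN5CCCC5)cc3F)CC4)cc12` gives 4.8 L/kg;
compound 2 `Nc1noc2ccc(-n3nc(C(F)(F)F)c4c3C(=O)N(c3ccc(-c5ccccc5CN5CCCC5)cc3)CC4)cc12` gives 5 L/kg.

Compound 2 stands alongside compound 1 in this assay, the two separated only by a 1.0-fold higher number from compound 1 to compound 2 (0.02 log units; within the scatter), a gap within the scatter, so neither can be placed ahead of the other. The unmeasured compound 3 `CNCc1ccccc1-c1ccc(N2CCc3c(C(F)(F)F)nn(-c4ccc5onc(N)c5c4)c3C2=O)cc1` differs from compound 2 in one place: methylamino in place of pyrrolidin-1-yl on a saturated chain carbon bound to an aromatic carbon. Among the compounds with values here, the single measured step, from compound 1 to compound 2, concerns a different change, hydrogen in place of fluoro on an aromatic carbon, and it amounted to a 1.0-fold higher number from compound 1 to compound 2 (0.02 log units; within the scatter); no measured pair shows pyrrolidin-1-yl replaced by methylamino. The data thus offer no direct guide to this change, and the expectation rests on the unchanged shared core. The expected step is a 1.3-fold lower number from compound 2 to compound 3 (0.10 log units; within the scatter), a shift not expected to pass beyond the scatter. The estimate for compound 3 in this assay is 4 L/kg, with a range from 2 L/kg to 8 L/kg.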

Compound 3, volume of distribution at steady state: 9.7 L/kg
Estimate against measurement, compound 3: 2.4-fold (0.38 log units) below; the measured number lies above the stated range.
By their numbers in this assay, from the lowest: compounds 1, 2 and 3 (each within the scatter of the next, the first and the last beyond it).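

At the saturated chain carbon bound to an aromatic carbon, exchanging pyrrolidin-1-yl for methylamino gives, in this assay, a 1.9-fold higher number from compound 2 to compound 3 (0.29 log units; within the scatter). Within the data shown here, this is the first measured step at this place, and it shows that the five-membered ring can give way to an open group of 2 heavy atoms, with 1 hydrogen-bond donor where there was none, without the step passing beyond the scatter. No available evidence accounts for the size of this step.

Still open, going by these compounds, is whether a piperidine ring, a dimethylamino group or a primary amine on the same carbon would also stay within the scatter of compound 2. Also open, on these data alone, is whether the methylamino exchange would read the same with the fluoro of compound 1 in place.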